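This account rests on a few compounds, and the source may have more. Where it says the series, first, only, none or still open, it means among the compounds named here.

Two compounds in the series have numbers in an assay on isolated protein for displacement of a labelled ligand from 5-hydroxytryptamine receptor 6 (Homo sapiens); a higher number here means a weaker inhibitor, a lower number a stronger inhibitor. Compound 1 `CN(C)CC1CCCc2cc(S(=O)(=O)c3ccccc3)ccc21` gives 0.0631 nM. Among the compounds with values here, compound 2 `O=S(=O)(c1cccc(F)c1)c1ccc2c(c1)CCC[C@H]2CN1CCCS1(=O)=O` gives 31.6 nM, the highest of the two numbers so far; its gap to compound 1 lies well beyond the scatter, but the two structures differ in more than one place, so no single step can be read from the pair. Compound 3 `O=C1CN(C[C@@H]2CCCc3cc(S(=O)(=O)c4cccc(F)c4)ccc32)CCN1` has not been measured in this assay. It differs from compound 2 by a group of 7 heavy atoms (4 carbon, 2 nitrogen, 1 oxygen; one six-membered non-aromatic ring with 2 hetero atoms) in place of a group of 7 heavy atoms (3 carbon, 1 nitrogen, 2 oxygen, 1 sulfur; one five-membered non-aromatic ring with 2 hetero atoms), on a saturated chain carbon bound to a saturated ring carbon, and everything else, including the fluorine on the sulfonyl-bearing phenyl, stays as in compound 2. Within the data shown here, no step between measured compounds carries this change, so its size cannot be taken from the data. The expected step is an 11-fold lower number from compound 2 to compound 3 (1.02 log units; beyond the scatter), downward in number and beyond the scatter, because compound 1, which carries a different nitrogen-containing group on a saturated chain carbon bound to a saturated ring carbon, gives 0.0631 nM. The number for compound 3 is estimated at 3 nM, with a range from 0.5 nM to 20 nM.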

Compound 3, inhibition constant: 6.31 nM
Beside the measured number, compound 3's estimate is 2.1-fold (0.32 log units) below it; the range from low to high includes it.
By their numbers in this assay, from the lowest: compound 1; then compound 3; then compound 2.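

At the saturated chain carbon bound to a saturated ring carbon, the series now has its first readable step in this assay, a 5.0-fold lower number from compound 2 to compound 3 (0.70 log units; beyond the scatter), so this place responds to the group it carries while the rest of compound 2, including the fluorine, stays fixed. The two groups match in heavy-atom count and in hydrogen-bond acceptor count, yet they differ in ring size and composition, and 3-oxopiperazin-1-yl alone carries a hydrogen-bond donor, so heavy-atom count alone does not set the number at this place. Nothing at hand links the step to any one of these differences.

Compound 1 differs from compound 3 in more than one place, and its number is much lower. Within the data shown here, the group on the chain carbon and the fluorine both differ between the two, and no step reads either change alone. Still open, from the compounds shown here alone, is how a piperidine, a morpholine or a carboxylic acid would compare with 3-oxopiperazin-1-yl at this place with the fluorine kept, and what a longer chain carrying the same ring would do.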